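This account rests on a few compounds, and the source may have more. Where it says the series, first, only, none or still open, it means among the compounds named here.

Compound 1 `CCOc1cc(N)c(Cl)cc1C(=O)CCCCN1CCCCC1` in a functional assay for antagonist activity at 5-hydroxytryptamine receptor 4 (Rattus norvegicus) (a higher number here means a more potent compound, by a factor of ten per unit of this negative logarithm, a lower number a less potent compound), gives < 7, a limit of the assay rather than a number.
Compound 2 `COc1cc(COc2cc(N)c(Cl)cc2C(=O)CCCCN2CCC(C)CC2)cc(OC)c1` gives 8.3.
Compound 3 `CCCC1CCN(CCCCC(=O)c2cc(Cl)c(N)cc2OCc2cc(OC)cc(OC)c2)CC1` gives 7.7.

Among the two numbers that are not limits, compound 3 stands lowest; the single measured step that reaches it is a number 0.60 log units lower from compound 2 to compound 3 (beyond the scatter), and the remaining value, that of compound 1, is a limit (the limit of < 7 in this assay, at which 1 of the 3 values shown sits). The unmeasured compound 4 `COc1cc(COc2cc(N)c(Cl)cc2C(=O)CCCCN2CCC(NC(N)=O)CC2)cc(OC)c1` differs from compound 3 in one place: ureido in place of propyl on a saturated ring carbon. Among the measured compounds shown here, the only measured step concerns the same saturated ring carbon, where a longer chain lowered the number modestly, as seen in a number 0.60 log units lower from compound 2 to compound 3 (beyond the scatter). For the measured compounds named here, no measured pair exchanges a carbon chain for a ureido group, so that step gives only an indirect guide to the direction for compound 4. Compound 4 is therefore expected to land near the values of compound 2 and compound 3, with a wide range, estimated at 7.9 between 7 and 8.7. The step expected from compound 3 to compound 4 is a number 0.20 log units higher from compound 3 to compound 4 (within the scatter).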

Compound 4, negative logarithm of the antagonist equilibrium constant: 8.5
Compound 4: the middle estimate sits 0.60 log units below what was measured, within the range that was stated.
By their numbers in this assay, from the lowest: compound 3; then compounds 2 and 4 (each within the scatter of the next). At a limit, below all of these: compound 1.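

Among the compounds shown here, at this saturated ring carbon, three ring bonds from the ring nitrogen, the earlier compounds carried only carbon chains, and ureido is the first group there with nitrogen, oxygen and hydrogen-bond donors. In this assay, putting it in place of propyl gives a number 0.80 log units higher from compound 3 to compound 4 (beyond the scatter), so a chain is not needed at this carbon for a high value. In place of methyl it gives a number 0.20 log units higher from compound 2 to compound 4 (within the scatter), which means that two groups with such different atoms cannot be told apart here, and nothing in the data shown accounts for this.

Going by these compounds, it remains open whether the whole ureido group matters or only part of it, which an amine or an acetamide on the same carbon would address. A carboxylic acid there, or a longer chain such as butyl, would also show how far this position tolerates change.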